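Trifluoromethylphenyl for Methylphenyl on the Amide Nitrogen

The source may hold more compounds than are shown below. What is called first, only, known or untested is meant among the compounds shown, and "the series" means these compounds.

Compound 3 `COc1cc2ncnc(NCc3cccc(NC(=O)Nc4ccc(C)cc4)c3)c2cc1OC` carries a 4-methylphenyl on an amide-type nitrogen. In a functional assay on MGC-803 cells (Homo sapiens) for antiproliferative activity, read by MTT assay (a lower number here means a stronger inhibitor, a higher number a weaker inhibitor), compound 3 gives 34200 nM, the highest of the two numbers in hand. Its nearest neighbour, compound 2 `Cc1ccc(NC(=O)Nc2cccc(CNc3ncnc4ccccc34)c2)cc1`, gives 31200 nM in this assay, a gap within the scatter. Compound 1 `Cc1ccccc1NC(=O)Nc1cccc(CNc2ncnc3ccccc23)c1` reports only a limit of > 50000 nM in this assay. Among the measured compounds shown here, the single measured step, an at least 1.6-fold lower number from compound 1 to compound 2 (0.20 log units; that floor lies within the scatter), rests on the limit of > 50000 nM in this assay, at which 1 of the 3 values shown sits, and concerns only the methyl on the phenyl.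

Compound 4 `COc1cc2ncnc(NCc3cccc(NC(=O)Nc4cccc(C(F)(F)F)c4)c3)c2cc1OC` differs from compound 3 in one place: 3-(trifluoromethyl)phenyl in place of 4-methylphenyl on an amide-type nitrogen. For the measured compounds named here, no measured step carries a trifluoromethyl, and the one aryl swap seen so far gives no reason to expect a move beyond the scatter in this assay. The step that this change is expected to produce, a 1.1-fold lower number from compound 3 to compound 4 (0.06 log units; within the scatter), is estimated to stay within the scatter. The estimate for compound 4 in this assay is 30000 nM, within a range from 10000 nM to 60000 nM.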

Compound 4, half-maximal inhibitory concentration: > 50000 nM
Compound 4: no number, only a limit (the forecaster's own chance of this, stated with the estimate: 25%); middle value at least 1.6-fold (0.22 log units) from the limit.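

Placing 3-(trifluoromethyl)phenyl in place of 4-methylphenyl on the amide-type nitrogen gives an at least 1.4-fold higher number from compound 3 to compound 4 (0.16 log units; that floor lies within the scatter) in this assay, the first step read at this place on the core of compound 3. In this assay compound 4 gives > 50000 nM, which is a limit and not a number, so the step has only a floor. The swap brought no lower number, and the limit now caps a larger share of the series: the limit of > 50000 nM in this assay, at which 2 of the 4 values shown sit.

The compounds shown do not separate the trifluoromethyl itself from its place on the phenyl, and the true size of the step stays open. Nor do they say how a plain phenyl or a phenyl carrying an amine on this nitrogen would read in this assay.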